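The source may hold more compounds than are shown below. What is called first, only, known or untested is meant among the compounds shown, and "the series" means these compounds.

Measured in a functional assay on the whole organism with Mus musculus as the target; a lower number here means that less compound is needed, a higher number that more compound is needed for the effect:
Compound 1 `CN(c1ccncc1)n1cccc1`: > 20 mg/kg
Compound 2 `CCN(c1ccncc1)n1cccc1`: > 20 mg/kg
Compound 3 `C=CCN(c1ccncc1)n1cccc1`: > 20 mg/kg

All three readings are limits of the assay, not numbers: the limit of > 20 mg/kg in this assay, at which 3 of the 3 values shown sit. Compound 3 therefore has no numerical standing, and its reading is only the limit > 20 mg/kg.

Compound 4 `C#CCN(c1ccncc1)n1cccc1` has yet to be measured. It differs from compound 3 in a single group: ethynyl in place of vinyl on a saturated chain carbon bound to a nitrogen on an aromatic ring. Cut one bond further out, the same change reads allyl to propargyl.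

Three measured steps at this place bear on the change: a step that the two limits leave unreadable from compound 1 to compound 2, a step that the two limits leave unreadable from compound 1 to compound 3 and a step that the two limits leave unreadable from compound 2 to compound 3. None of them has a readable size, so they provide neither a size nor a direction to carry over. In this assay, no step beyond the usual scatter is therefore expected, and the estimate stays close to the limit of compound 3. The expected change is a step that the limit leaves unreadable from compound 3 to compound 4. For compound 4 the estimated value is 25 mg/kg, with an expected range of 10 mg/kg to 60 mg/kg.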

Compound 4, dose for half-maximal effect: > 20 mg/kg
Compound 4 gave a limit, no number; the forecaster's own chance of this, stated with the estimate: 70%; the middle value does not contradict the limit.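

In this assay compound 4 gives > 20 mg/kg, a limit and not a number. Among the compounds shown here, no step among compound 1, compound 2, compound 3 and compound 4 can be read: the limit of > 20 mg/kg in this assay, at which 4 of the 4 values shown sit. The compounds shown leave open whether any of these chains on the shared core has a measurable dose in this assay, and how they would rank.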